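Methoxy addition on the pendant ring of the pyrazoline series

The compounds below may be only part of what the source reports. "The series", "measured", "known", "first", "only" and "open" are said of these compounds alone.

Among the measured compounds shown here, compound 2 `COc1ccc(C2CC(c3cc(Cl)c(C)cc3O)=NN2c2ccc(S(N)(=O)=O)cc2)cc1OC` is the weaker of the two compounds measured so far in a functional assay on TK-10 cells (Homo sapiens) for antiproliferative activity, with a stated time of 48 h; on this read-out higher numbers stand for weaker inhibition of growth and lower numbers for stronger inhibition of growth: compound 2 gives 18400 nM, whereas compound 1 `Cc1cc(O)c(C2=NN(c3ccc(S(N)(=O)=O)cc3)C(c3ccccc3Cl)C2)cc1Cl` gives 5860 nM, the difference being a 3.1-fold higher number from compound 1 to compound 2 (0.50 log units; beyond the scatter). Compound 3 `COc1ccc(C2CC(c3cc(Cl)c(C)cc3O)=NN2c2ccc(S(N)(=O)=O)cc2)c(OC)c1OC` has not yet been measured. Relative to compound 2 the change is methoxy in place of hydrogen on an aromatic carbon. For the measured compounds named here, the only measured step touches the same pendant aryl ring, but it exchanges the whole substituent pattern rather than adding one group, so it bears on the new step only loosely. It shows that altering this ring shifts the number by a modest amount in this assay. Going by the values given here, a further methoxy on an already dimethoxylated ring is expected to move the number little, if at all, with the direction of the one known step pointing weakly toward a higher value. Compound 3 is therefore expected near 25000 nM, in the range 9000 nM to 70000 nM, a step of a 1.4-fold higher number from compound 2 to compound 3 (0.13 log units; within the scatter) that should stay within or barely beyond the scatter.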

Compound 3, concentration for total growth inhibition: 6600 nM
The estimate for compound 3 lay 3.8-fold (0.58 log units) above the measured number, and the stated range ends above it.
By their numbers in this assay, from the lowest: compounds 1 and 3 (each within the scatter of the next); then compound 2.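

In this assay, adding one methoxy to the pendant ring is not a silent change: going from 3,4-dimethoxyphenyl to 2,3,4-trimethoxyphenyl gives a 2.8-fold lower number from compound 2 to compound 3 (0.45 log units; beyond the scatter), opposite in direction to a 3.1-fold higher number from compound 1 to compound 2 (0.50 log units; beyond the scatter). With a 1.1-fold higher number from compound 1 to compound 3 (0.05 log units; within the scatter), the 2,3,4-trimethoxyphenyl and 2-chlorophenyl rings cannot be told apart on this read-out, so among these three compounds only compound 2 stands apart, and methoxy groups on this ring do not in themselves go with a higher number. No available data explain the step.

On these data alone, whether the shift is specific to methoxy on this carbon, ortho to a large group, remains open; a hydroxyl, a fluorine or an amine there would test this. Also open, as far as these compounds go, is whether the same methoxy would shift the number on a ring without the 3,4-dimethoxy pattern.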